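Swapping a carbamate cap for a fluorinated ring on the piperidine

The source may report more compounds than this note shows. Statements on the series, on what has been measured and on what is new or still open speak of the compounds shown alone.

Compound 1 `CC(C)S(=O)(=O)c1cnc(O[C@H]2CC[C@H](OC3CCN(C(=O)OC(C)(C)C)CC3)CC2)cn1`: 18.5 nM
Compound 2 `CC1(OC(=O)N2CCC(O[C@H]3CC[C@H](Oc4cnc(S(C)(=O)=O)cn4)CC3)CC2)CC1`: 25.9 nM

In a functional assay on isolated protein for agonist activity at Glucose-dependent insulinotropic receptor (Homo sapiens), read by HTRF and cAMP accumulation (a higher number here means that more compound is needed for the effect, a lower number that less compound is needed), compound 2 gives the higher of the two numbers, but its gap to compound 1 lies within the scatter, so the two cannot be ordered. Compound 3 `CS(=O)(=O)c1cnc(O[C@H]2CC[C@H](OC3CCN(CC4(C(F)(F)F)CCCC4)CC3)CC2)cn1` differs from compound 2 by a group of 10 heavy atoms (7 carbon, 3 fluorine; one five-membered non-aromatic ring of carbon only) in place of a group of 7 heavy atoms (5 carbon, 2 oxygen; one three-membered non-aromatic ring of carbon only), on an amine nitrogen in a ring. Going by the values given here, no measured pair shows a change of this kind, so no direction can be read from the data. A step from compound 2 to compound 3 within the scatter, a 1.2-fold higher number from compound 2 to compound 3 (0.06 log units; within the scatter), is therefore expected. Compound 3 is estimated at 30 nM, between 8 nM and 120 nM.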

Compound 3, half-maximal effective concentration: 48.8 nM
Estimate against measurement, compound 3: 1.6-fold (0.21 log units) below; low and high end bracket the measured number.
By their numbers in this assay, from the lowest: compounds 1, 2 and 3 (each within the scatter of the next, the first and the last beyond it).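

On the amine nitrogen in the ring, the ((1-methylcyclopropyl)oxy)carbonyl cap gives way to a carbon-only five-membered ring group bearing three fluorines and no hydrogen-bond acceptors, and in this assay the change stays small (a 1.9-fold higher number from compound 2 to compound 3 (0.28 log units; within the scatter)). In this pair, then, the number holds without the carbamate carbonyl. No measurement shown accounts for this result.

Open, on these data alone, is whether the fluorines matter: the same group with a plain methyl in place of trifluoromethyl would test that. A simple amide on that nitrogen is also still to be compared.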